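Switching the amine substituent back to a chlorobenzyl group

The compounds below may be only part of what the source reports. "The series", "measured", "known", "first", "only" and "open" are said of these compounds alone.

Measured so far:
- compound 1 `COc1cc(N)c(Cl)cc1NC(=O)C1CCN(Cc2ccc(Cl)cc2)CC1` gives 1.2 mg/kg in a functional assay on the whole organism for antagonist activity, with Mus musculus as the target; on this read-out lower numbers stand for an effect already at smaller amounts and higher numbers for an effect only at larger amounts of compound
- compound 2 `COc1cc(N)c(Cl)cc1NC(=O)C1CCN(C2CCCC2)CC1` gives > 10 mg/kg in this assay, a limit of the assay rather than a number
- compound 3 `CCCCCCN1CCC(C(=O)Nc2cc(Cl)c(N)cc2OC)CC1` gives > 10 mg/kg in this assay, again a limit and not a number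

Compound 3 thus sits at the upper edge of what this assay reports; it shares this standing with one other compound, as the limit of > 10 mg/kg in this assay, at which 2 of the 3 values shown sit, records. Compound 1 alone gives a number. The measured steps both lead away from compound 1: an at least 8.3-fold higher number from compound 1 to compound 2 (0.92 log units; beyond the scatter) and an at least 8.3-fold higher number from compound 1 to compound 3 (0.92 log units; beyond the scatter). The step that the two limits leave unreadable from compound 2 to compound 3 cannot be sized, both ends being limits.

Compound 4 `COc1cc(N)c(Cl)cc1NC(=O)C1CCN(Cc2cccc(Cl)c2)CC1` is not yet measured. Its difference from compound 3: 3-chlorophenyl in place of pentyl on a saturated chain carbon bound to an amine nitrogen in a ring. This is close to the reverse of the step from compound 1 to compound 3, where pentyl replaced 4-chlorophenyl and the number rose by at least the recorded amount. The chlorine now sits on the 3-position of the phenyl rather than the 4-position, so the return need not be complete. The expectation is a drop in this assay, of size an at least 5.0-fold lower number from compound 3 to compound 4 (0.69 log units; beyond the scatter), bringing compound 4 back toward compound 1. Compound 4 is therefore estimated at 2 mg/kg, with a range from 0.8 mg/kg to 6 mg/kg.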

Compound 4, dose for half-maximal effect: > 4 mg/kg
Compound 4: no number, only a limit (the forecaster's own chance of this, stated with the estimate: 15%); at least 2.0-fold (0.30 log units) between middle value and limit.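

On a saturated chain carbon bound to an amine nitrogen in a ring, 3-chlorophenyl in place of 4-chlorophenyl keeps the aromatic ring and the chlorine and changes only where the chlorine sits, and in this assay this alone gives an at least 3.3-fold higher number from compound 1 to compound 4 (0.52 log units; beyond the scatter). A chlorophenyl group at this place therefore does not by itself restore the value of compound 1, which points to the 4-chlorophenyl group rather than to any chlorophenyl group, though only these two are shown. The value of compound 4 is a limit and not a number: the limit of > 4 mg/kg in this assay, at which 1 of the 4 values shown sits.

The steps from compound 2 and from compound 3 to compound 4 cannot be read, as both ends of each are limits, so the comparison of 3-chlorophenyl with pentyl and of 3-chlorobenzyl with cyclopentyl stays undecided.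

Open, from the compounds shown here alone, is how far compound 4 actually lies from compound 1, since the step gives only a minimum size. Also open, going by these compounds, is how a plain phenyl or a 4-bromophenyl at this place would compare with the 4-chlorophenyl of compound 1.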